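The source may report more compounds than this note shows. Statements on the series, on what has been measured and on what is new or still open speak of the compounds shown alone.

Measured so far:
- compound 1 `Cc1cccc(C(=O)NCN2CCC(c3ccccn3)CC2)c1`: 67%
- compound 2 `Cc1cc(C)cc(NC(=O)CN2CCC(c3cccc[n+]3[O-])CC2)c1`: 76%
- compound 3 `Cc1cccc(NC(=O)CN2CCC(c3ccccc3)CC2)c1`: 37%

In a functional assay on HEK293 cells for agonist activity at D(4) dopamine receptor (Homo sapiens), read by FLIPR (a lower number here means a smaller maximal response, a higher number a larger maximal response), compound 2 gives 76%, the largest figure among the three. Compound 1 stands closest to it, and the gap between the two is within the usual scatter of the assay, so they cannot be told apart on these numbers. Compound 3 stands furthest away, and its gap to compound 2 is beyond the scatter.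

Compound 4 `Cc1cc(F)ccc1NC(=O)CN1CCC(c2cccc[n+]2[O-])CC1` has not yet been measured. It differs from compound 2 in one place: 4-fluoro-2-methylphenyl in place of 3,5-dimethylphenyl on an amide-type nitrogen. Among the compounds with values here, no pair of measured compounds differs in just this way, so there is no measured step to lean on. Given that, the change is expected to shift the maximal response only a little, if at all, in either direction. Compound 4 is therefore expected to give about 70%, with a range from 50% to 90%. That corresponds to an expected step of a number 6 percentage points lower from compound 2 to compound 4 (within the scatter), which would not be beyond the scatter.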

Compound 4, largest response reached (reported as efficacy), in percent of the reference or control that the assay uses: 84%
Compound 4: middle estimate off by 14 percentage points, on the low side, and the stated range covers the measured number.
By their numbers in this assay, from the lowest: compound 3; then compounds 1, 2 and 4 (each within the scatter of the next, the first and the last beyond it).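

In this assay, within the data shown here, putting 4-fluoro-2-methylphenyl in place of 3,5-dimethylphenyl on the amide-type nitrogen gives a number 8 percentage points higher from compound 2 to compound 4 (within the scatter), the first measured step at this position. The maximal response therefore holds up when this aromatic ring is exchanged for one with the same heavy-atom count, in which a fluorine takes the place of one carbon and the methyl pattern differs. Nothing available explains why the response stays at this level.

Because the two groups differ in both their fluorine and their methyl pattern, the share of each change cannot be separated here. As far as these compounds go, it also remains open how a chlorine or methoxy group in place of the fluorine, or a cyclohexyl group in place of the whole aromatic ring, would fare on this nitrogen.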